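Pyrrolidine nitrogen substituents in the shared core series

The source may report more compounds than this note shows. Statements on the series, on what has been measured and on what is new or still open speak of the compounds shown alone.

Compound 3 `CNC(=O)CN1CC[C@H](n2c(Nc3ccc(F)cc3)nc3cnc(Nc4ccc(N5CCN(C)CC5)cc4)nc32)C1` gives 1520 nM in a functional assay on HCC827 cells (Homo sapiens) for antiproliferative activity, read by MTT assay, with a stated time of 72 h; a lower number here means a stronger inhibitor, a higher number a weaker inhibitor. Of the three measured numbers it is the second highest. Its nearest neighbour is compound 2 `CCOC(=O)CN1CC[C@H](n2c(Nc3ccc(F)cc3)nc3cnc(Nc4ccc(N5CCN(C)CC5)cc4)nc32)C1`, which gives 1810 nM; the two lie within the scatter of each other, so no order between them is claimed. The lowest number belongs to compound 1 `CN1CCN(c2ccc(Nc3ncc4nc(Nc5ccc(F)cc5)n([C@@H]5CCNC5)c4n3)cc2)CC1`, which gives 300 nM, the step being a 5.1-fold higher number from compound 1 to compound 3 (0.70 log units; beyond the scatter).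

Compound 4 `CN1CCN(c2ccc(Nc3ncc4nc(Nc5ccc(F)cc5)n([C@@H]5CCN(C(=O)CO)C5)c4n3)cc2)CC1` differs from compound 3 in one place: 1-((hydroxymethyl)carbonyl)pyrrolidin-3-yl in place of 1-((methylcarbamoyl)methyl)pyrrolidin-3-yl on an aromatic nitrogen.

Going by the values given here, two measured steps bear on this. Both a 6.0-fold higher number from compound 1 to compound 2 (0.78 log units; beyond the scatter) and a 5.1-fold higher number from compound 1 to compound 3 (0.70 log units; beyond the scatter) show that carrying a substituent on the pyrrolidin-3-yl nitrogen, whether the ester-bearing or the methylcarbamoyl-bearing chain, gives a modest rise in the number relative to the bare pyrrolidin-3-yl. The exchange of ester for methylamide, a 1.2-fold lower number from compound 2 to compound 3 (0.08 log units; within the scatter), stays within the scatter. Among the compounds with values here, compound 4 again carries a substituent at that nitrogen, now the 1-((hydroxymethyl)carbonyl) group, for which no measured step exists. The nearest guide is the pair of compounds 2 and 3, and no step beyond the scatter is expected; the estimated step is a 1.2-fold lower number from compound 3 to compound 4 (0.07 log units; within the scatter). Compound 4 is therefore expected to give about 1300 nM in this assay, with a range of 500 nM to 3400 nM.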

Compound 4, half-maximal inhibitory concentration: 350 nM
Beside the measured number, compound 4's estimate is 3.7-fold (0.57 log units) above it; the whole stated range lies above it.
By their numbers in this assay, from the lowest: compounds 1 and 4 (each within the scatter of the next); then compounds 3 and 2 (each within the scatter of the next).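

In this assay, a substituent on the amine nitrogen in the ring of the pyrrolidin-3-yl group does not by itself go with a higher number: with (hydroxymethyl)carbonyl in place of hydrogen there is a 1.2-fold higher number from compound 1 to compound 4 (0.07 log units; within the scatter), so compound 4 and compound 1 stand within the scatter of each other. The rise seen earlier therefore belongs to the two chains of compound 2 and compound 3 rather than to substitution at this nitrogen in general, as the exchange of either chain for 1-((hydroxymethyl)carbonyl)pyrrolidin-3-yl shows, with a 4.3-fold lower number from compound 3 to compound 4 (0.64 log units; beyond the scatter) and a 5.2-fold lower number from compound 2 to compound 4 (0.71 log units; beyond the scatter). Nothing shown accounts for this difference between the substituents.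

Still open, from the compounds shown here alone, is which part of the (hydroxymethyl)carbonyl group goes with this result, the carbonyl or the hydroxy group. An acetyl or a 2-hydroxyethyl group on the same nitrogen would separate the two, while a longer chain or a carboxylic acid at the end of the substituent would show how far this tolerance extends.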